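This account rests on a few compounds, and the source may have more. Where it says the series, first, only, none or still open, it means among the compounds named here.

In an assay on HeLa cells for inhibition of 17-beta-hydroxysteroid dehydrogenase type 3 (Homo sapiens) (on this read-out higher numbers stand for weaker inhibition and lower numbers for stronger inhibition), three close relatives of a shared core have been measured. Compound 1 `O=c1cc(CSc2ccncc2)c2ccc(O)cc2o1` gives 5000 nM. Compound 2 `O=c1cc(CSc2ncccn2)c2ccc(O)cc2o1` gives 1000 nM, and compound 3 `O=c1cc(CSc2cccs2)c2ccc(O)cc2o1` gives 420 nM, the lowest of the three. The measured steps all change only the aromatic ring on the sulfur: a 5.0-fold lower number from compound 1 to compound 2 (0.70 log units; beyond the scatter), a 12-fold lower number from compound 1 to compound 3 (1.08 log units; beyond the scatter) and a 2.4-fold lower number from compound 2 to compound 3 (0.38 log units; beyond the scatter). Compound 4 `O=c1cc(CSc2nncs2)c2ccc(O)cc2o1` keeps the core and the sulfur link and introduces (1,3,4-thiadiazol-2-yl in place of thiophen-2-yl on a sulfur). Among the measured compounds shown here, no measured step puts nitrogen into a five-membered ring, so the nearest guide is the move from compound 2 to compound 3, where a nitrogen-containing six-membered ring became a thiophene ring and the number fell; reading that step backwards, swapping a thiophene for a ring richer in nitrogen is expected to raise the number modestly, while compound 1 shows that nitrogen rings are not uniformly weak. For compound 4 the expected step is a 2.4-fold higher number from compound 3 to compound 4 (0.38 log units; beyond the scatter). Compound 4 is therefore estimated at 1000 nM, within a range of 300 nM to 4000 nM.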

Compound 4, half-maximal inhibitory concentration: 200 nM
Beside the measured number, compound 4's estimate is 5.0-fold (0.70 log units) above it; the measured number lies below the stated range.
By their numbers in this assay, from the lowest: compound 4; then compound 3; then compound 2; then compound 1.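

In this assay, putting 1,3,4-thiadiazol-2-yl in place of thiophen-2-yl on the sulfur gives a 2.1-fold lower number from compound 3 to compound 4 (0.32 log units; beyond the scatter), so among these four compounds, nitrogen in the ring on the sulfur does not by itself go with a higher number. Among the compounds shown here, the thiadiazole also stands clear of both six-membered nitrogen rings, with a 5.0-fold lower number from compound 2 to compound 4 (0.70 log units; beyond the scatter) and a 25-fold lower number from compound 1 to compound 4 (1.40 log units; beyond the scatter), and in this small set both five-membered rings give lower numbers than both six-membered rings, with no compound going against that order. Nothing given here explains these differences.

As far as these compounds go, it remains open whether another five-membered ring, such as a thiazole or a triazole, would fit the same order. Also open, from the compounds shown here alone, is how a methyl or an amine added to the thiadiazole, or an oxygen in place of the linking sulfur, would move the number.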